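The source may hold more compounds than are shown below. What is called first, only, known or untested is meant among the compounds shown, and "the series" means these compounds.

Working notes on the series. Compound 1 `COc1ccc(Cn2nc(Nc3cc(C)[nH]n3)c3ccccc3c2=O)cc1` gives 4200 nM in a functional assay on COLO 205 cells (Homo sapiens) for cytotoxicity; a higher number here means a weaker inhibitor, a lower number a stronger inhibitor. Compound 2 `CC(=O)Nc1ccc(Cn2nc(Nc3cc(C)[nH]n3)c3ccccc3c2=O)cc1` sits at the limit of > 30000 nM in this assay, at which 1 of the 3 values shown sits; in this assay compound 2 gives > 30000 nM, which is a limit of the assay and not a number. Going by the values given here, the only measured step, an at least 7.1-fold higher number from compound 1 to compound 2 (0.85 log units; beyond the scatter), is at least modest. Compound 3 `Cc1cc(Nc2nn(Cc3ccc([N+](=O)[O-])cc3)c(=O)c3ccccc23)n[nH]1` has no result in this assay; its entry reads "not determined" (no result reported), so it stands nowhere on the numbers shown. Compound 4 `Cc1cc(Nc2nn(Cc3ccc(S(C)(=O)=O)cc3)c(=O)c3ccccc23)n[nH]1` differs from compound 3 by methylsulfonyl in place of nitro on an aromatic carbon. Among the compounds with values here, no measured step covers this change, and compound 3 offers no anchor, so no step size or direction can be set from the data; the step from compound 1 to compound 2 shows only that a change on an aromatic carbon can weaken potency. Compound 4 is estimated in this assay at 15000 nM, within 3000 nM to 40000 nM, with a real chance of a limit only.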

Compound 4, half-maximal inhibitory concentration: 4500 nM
Compound 4: middle estimate off by 3.3-fold (0.52 log units), on the high side, within the range that was stated.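

At this position, on an aromatic carbon para to a large group, acetamido is not the only polar-looking option to test: in this assay, methylsulfonyl in place of acetamido gives an at least 6.6-fold lower number from compound 2 to compound 4 (0.82 log units; beyond the scatter). Compound 2 stands at a limit of the assay and not at a number: the limit of > 30000 nM in this assay, at which 1 of the 4 values shown sits. Methylsulfonyl in place of methoxy gives a 1.1-fold higher number from compound 1 to compound 4 (0.03 log units; within the scatter), so among the measured compounds only acetamido stands apart.

The step from nitro to methylsulfonyl cannot be read, as compound 3 has no result. As far as these compounds go, whether an amine or a carboxylic acid here would group with methoxy and methylsulfonyl or with acetamido remains open.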